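Cyclic imide in place of an aryl thiourea on the shared core

A few compounds are considered here, and "the series" means these few. Any claim that something is new, unique, unknown or untested is made for them only; others in the source may bear on it.

Compound 1 `N#CC1=C(NC(=S)Nc2ccccc2)N(c2ccc(S(N)(=O)=O)cc2)C2=C(C(=O)CCC2)C1c1ccc(Cl)cc1Cl` is tested in a functional assay on Ehrlich cells (Mus musculus) for cytotoxicity, read by trypan blue exclusion, with a stated time of 2 h, tested at 10 ug/mL (a lower number here means a weaker effect, a higher number a stronger effect of the compound at the concentration tested), and gives 40%, the second highest of the three numbers. Compound 2 `N#CC1=C(NC(=S)Nc2ccc(Br)cc2)N(c2ccc(S(N)(=O)=O)cc2)C2=C(C(=O)CCC2)C1c1ccc(Cl)cc1Cl` gives 50%, and a number 10 percentage points higher from compound 1 to compound 2 (within the scatter) lies within the scatter. Compound 3 `N#CC1=C(NC(=O)CCC(=O)O)N(c2ccc(S(N)(=O)=O)cc2)C2=C(C(=O)CCC2)C1c1ccc(Cl)cc1Cl` gives 20%. Compound 4 `N#CC1=C(N2C(=O)CCC2=O)N(c2ccc(S(N)(=O)=O)cc2)C2=C(C(=O)CCC2)C1c1ccc(Cl)cc1Cl` is not yet measured; it differs from compound 1 in that (a group of 7 heavy atoms (4 carbon, 1 nitrogen, 2 oxygen; one five-membered non-aromatic ring with 1 hetero atom) in place of a group of 10 heavy atoms (7 carbon, 2 nitrogen, 1 sulfur; one six-membered aromatic ring of carbon only), on a double-bonded ring carbon). The step that bears most on this change is a number 20 percentage points lower from compound 1 to compound 3 (beyond the scatter), where the aryl thiourea also gave way to a chain bearing oxygen; a number 30 percentage points lower from compound 2 to compound 3 (beyond the scatter) points the same way. A modest fall is therefore expected, so a number 15 percentage points lower from compound 1 to compound 4 (beyond the scatter) is estimated. For compound 4 the expected reading is 25%, within a range of 10% to 40%.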

Compound 4, a percentage reported as activity, at one concentration (the size of the read-out at that concentration, not a potency): 20%
Compound 4: middle estimate off by 5 percentage points, on the high side; the measured number falls inside the stated range.
By their numbers in this assay, from the lowest: compounds 3 and 4 (each within the scatter of the next); then compounds 1 and 2 (each within the scatter of the next).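

In this assay, the 2,5-dioxopyrrolidin-1-yl ring, with no hydrogen-bond donors, gives a number 20 percentage points lower from compound 1 to compound 4 (beyond the scatter) and a number 30 percentage points lower from compound 2 to compound 4 (beyond the scatter), while no change at the digits printed from compound 3 to compound 4 (within the scatter). At this position, then, the closed ring and the open chain ending in a carboxylic acid cannot be told apart, and both read lower than the aryl thioureas. Nothing measured here explains the fall. Still open, from the compounds shown here alone, is whether the higher numbers go with the aromatic ring or the thiocarbonyl of the thiourea; a phenyl urea or a benzamide at this position would separate the two.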